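Anilino variation on a shared pyrimidine-type core: compound 4

The source may report more compounds than this note shows. Statements on the series, on what has been measured and on what is new or still open speak of the compounds shown alone.

Measured so far:
compound 1 `COc1ccc(Nc2nc(SCc3cn(Cc4ccccc4Cl)nn3)nc(-c3ccccc3)c2C#N)cc1` – 8050 nM
compound 2 `COc1ccccc1Nc1nc(SCc2cn(Cc3ccccc3Cl)nn2)nc(-c2ccccc2)c1C#N` – 6170 nM
compound 3 `Cc1cccc(Nc2nc(SCc3cn(Cc4ccccc4Cl)nn3)nc(-c3ccccc3)c2C#N)c1` – 19600 nM

In a functional assay on MCF7 cells (Homo sapiens) for inhibition, read by MTT assay, with a stated time of 72 h (a higher number here means a weaker inhibitor, a lower number a stronger inhibitor), compound 3 gives the highest of the three numbers. The step of a 2.4-fold higher number from compound 1 to compound 3 (0.39 log units; beyond the scatter) and the step of a 3.2-fold higher number from compound 2 to compound 3 (0.50 log units; beyond the scatter) both run toward weaker inhibition when 3-methylphenyl takes the place of a methoxyphenyl group on the nitrogen; the step of a 1.3-fold lower number from compound 1 to compound 2 (0.12 log units; within the scatter) between the two methoxyphenyl compounds stays within the scatter.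

Compound 4 `N#Cc1c(Nc2ccc(F)cc2)nc(SCc2cn(Cc3ccccc3Cl)nn2)nc1-c1ccccc1` is the next member. Its change from compound 3 is 4-fluorophenyl in place of 3-methylphenyl on a nitrogen on an aromatic ring. This reverses the kind of change seen in the two steps above: the 3-methylphenyl group, which brought the highest number, leaves, and a 4-fluorophenyl group enters, bearing its substituent in the same numbered position as the 4-methoxyphenyl group of compound 1. Within the data shown here, no measured step has a fluorine-bearing group, so the comparison with compound 1 is by analogy only.

On this basis a return toward the numbers of compound 1 and compound 2 is expected, so that a modest step of a 2.2-fold lower number from compound 3 to compound 4 (0.34 log units; beyond the scatter) toward stronger inhibition is estimated. For compound 4 the expected value in this assay is 9000 nM, with a range from 3500 nM to 25000 nM.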

Compound 4, half-maximal inhibitory concentration: 19900 nM
Estimate against measurement, compound 4: 2.2-fold (0.34 log units) below, and the stated range covers the measured number.
By their numbers in this assay, from the lowest: compounds 2 and 1 (each within the scatter of the next); then compounds 3 and 4 (each within the scatter of the next).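

Working notes: in this assay the exchange of 3-methylphenyl for 4-fluorophenyl on the nitrogen gives a 1.0-fold higher number from compound 3 to compound 4 (0.01 log units; within the scatter) and so leaves the number where it was, which means that moving to a group substituted like the 4-methoxyphenyl of compound 1 does not by itself restore the lower numbers. Among these compounds, the direct exchange of fluoro for methoxy on an aromatic carbon gives a 2.5-fold higher number from compound 1 to compound 4 (0.39 log units; beyond the scatter) and shows for the first time that the identity of this substituent counts, while the comparison with the other methoxyphenyl compound gives a 3.2-fold higher number from compound 2 to compound 4 (0.51 log units; beyond the scatter) in the same direction. Across these four compounds the two methoxyphenyl members hold the lower numbers wherever the methoxy stands, and neither compound 3 nor compound 4 goes against this.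

Still open, going by these compounds, is whether the lower numbers are specific to methoxy, or whether a hydroxy, an ethoxy or a dimethylamino group in place of fluoro on an aromatic carbon would sit with compound 1 or with compound 4. Nothing at hand bears on the reason for this difference between the methoxyphenyl compounds and the other two.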